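Swapping the Six-Membered Lactam for a Five-Membered Ring

A few compounds are considered here, and "the series" means these few. Any claim that something is new, unique, unknown or untested is made for them only; others in the source may bear on it.

Compound 1 `CC(C)C(c1nnc[nH]1)c1ccc(-c2ccc3cccc(F)c3c2)[nH]c1=O`, compound 2 `CC(C)C(c1ccc(-c2ccc3cccc(F)c3c2)[nH]c1=O)N1CCCCC1=O` and compound 3 `CC(C)C(c1ccc(-c2ccc3cccc(F)c3c2)[nH]c1=O)N1CCNC1=O` share one core and differ only in the group on a saturated chain carbon bound to an aromatic carbon and a saturated chain carbon. In an ADME assay on microsomes from liver (Rattus norvegicus) for metabolic stability (a lower number here means that the compound disappears faster, a higher number that the compound lasts longer), compound 1 gives 0.552 h, compound 2 gives 0.102 h and compound 3 gives 0.283 h. Compound 2 stands lowest of the three, with a 2.8-fold higher number from compound 2 to compound 3 (0.44 log units; beyond the scatter) to its nearest neighbour and a 5.4-fold lower number from compound 1 to compound 2 (0.73 log units; beyond the scatter) marking the wider gap. Compound 4 `CC(C)C(/C=C1/CCNC1=O)c1ccc(-c2ccc3cccc(F)c3c2)[nH]c1=O` carries a group of 7 heavy atoms (5 carbon, 1 nitrogen, 1 oxygen; one five-membered non-aromatic ring with 1 hetero atom) in place of a group of 7 heavy atoms (5 carbon, 1 nitrogen, 1 oxygen; one six-membered non-aromatic ring with 1 hetero atom), on a saturated chain carbon bound to an aromatic carbon and a saturated chain carbon. Going by the values given here, the step that bears on this change is the one already seen between compound 2 and compound 3, where a five-membered ring likewise replaced the six-membered one and the number rose beyond the scatter, so a modest rise is expected here too, a 2.0-fold higher number from compound 2 to compound 4 (0.29 log units; within the scatter). Compound 4 is therefore estimated at 0.2 h, within a range from 0.08 h to 0.5 h.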

Compound 4, half-life: 0.06 h
Estimate against measurement, compound 4: 3.3-fold (0.52 log units) above; measured number outside the range, below it.
By their numbers in this assay, from the lowest: compounds 4 and 2 (each within the scatter of the next); then compounds 3 and 1 (each within the scatter of the next).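

In this assay, a five-membered ring alone does not raise the number at this position: a 1.7-fold lower number from compound 2 to compound 4 (0.23 log units; within the scatter), so the new group stays level with the 2-oxopiperidin-1-yl group, while a 4.7-fold lower number from compound 3 to compound 4 (0.67 log units; beyond the scatter) and a 9.2-fold lower number from compound 1 to compound 4 (0.96 log units; beyond the scatter). The rise seen with the 2-oxoimidazolidin-1-yl group of compound 3 therefore does not follow from ring size alone. No measurement here gives a reason for these steps. Still open, going by these compounds, is how a simple amine or a carboxylic acid on this chain carbon would compare with the 4H-1,2,4-triazol-3-yl group of compound 1.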